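The source may report more compounds than this note shows. Statements on the series, on what has been measured and on what is new or still open speak of the compounds shown alone.

Of the compounds shown here, three have so far been measured in a physicochemical assay for solubility, at pH 7.4; a lower number here means a less soluble compound, a higher number a more soluble compound. Compound 1 `CC(C)CCn1nc(CC(C)(C)C)c(O)c(C2=NS(=O)(=O)c3cc(NS(C)(=O)=O)ccc3N2)c1=O` gives a value that is a limit of this assay rather than a number, > 100000 nM. Compound 2 `Cc1ccc(-c2nn(Cc3ccccc3)c(=O)c(C3=NS(=O)(=O)c4ccccc4N3)c2O)s1` likewise reaches a limit, > 80000 nM. Compound 3 `CN(c1ccc2c(c1)S(=O)(=O)N=C(c1c(O)c(-c3cccs3)nn(CCC(C)(C)C)c1=O)N2)S(C)(=O)=O` also sits at a limit, > 100000 nM. No exact number is therefore known for any of them: compound 3 stands at the limit of > 100000 nM in this assay, at which 2 of the 3 values shown sit, together with compound 1, while compound 2 sits at the limit of > 80000 nM in this assay, at which 1 of the 3 values shown sits. Among the measured compounds shown here, no step between measured compounds can be read off. Nothing is known about how any change in structure moves solubility within this series.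

Compound 4 `CC(C)CCn1nc(-c2cccs2)c(O)c(C2=NS(=O)(=O)c3cc(N(C)S(C)(=O)=O)ccc3N2)c1=O` is the compound still to be measured. It differs from compound 3 by hydrogen in place of methyl on a saturated chain carbon bound to three saturated chain carbons. For the measured compounds named here, with no measured step to lean on, the step in this assay is expected to be none beyond the scatter, in either direction. In this assay compound 4 is expected to give about 100000 nM, within a range of 50000 nM to 200000 nM. The step this means is expected to be a number no higher from compound 3 to compound 4 (the limit leaves the size open), and the most likely outcome is that the assay again reports only a limit.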

Compound 4, solubility: > 100000 nM
Compound 4: no number, only a limit; the forecaster's own chance of this, stated with the estimate: 80%; the middle value lies on the limit itself.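

In this assay compound 4 gives > 100000 nM as a limit, not a number. Among the compounds shown here, compound 3 likewise gives > 100000 nM as a limit, so no step between compound 3 and compound 4 can be read. The compounds shown leave open how swapping methyl for hydrogen on this chain carbon moves solubility, and what the exact solubility of each compound is.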